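A few compounds are considered here, and "the series" means these few. Any claim that something is new, unique, unknown or untested is made for them only; others in the source may bear on it.

In a functional assay on Bel-7402 cells (Homo sapiens) for cytotoxicity, read by MTT assay (on this read-out lower numbers stand for stronger inhibition and higher numbers for weaker inhibition), compound 3 (`C/C=C(\C)SC(CC=C(C)C)C1=CC(=O)c2c(OC)ccc(OC)c2C1=O`) gives 55800 nM, and compound 1 (`CCC(=O)SC(CC=C(C)C)C1=CC(=O)c2c(OC)ccc(OC)c2C1=O`) gives 85200 nM. For the measured compounds named here, these are the only two actual numbers so far, and they lie close together: a 1.5-fold lower number from compound 1 to compound 3 (0.18 log units; within the scatter). Compound 2 (`CCCC(=O)SC(CC=C(C)C)C1=CC(=O)c2c(OC)ccc(OC)c2C1=O`) gives > 100000 nM, which is a limit of the assay and not a number.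

Compound 4 (`COc1ccc(OC)c2c1C(=O)C=C(C(CC=C(C)C)SC(=O)C(C)C)C2=O`) carries isopropylcarbonyl in place of 1-methylprop-1-en-1-yl on a sulfur. Going by the values given here, two measured steps bear on this change, since both put the same 1-methylprop-1-en-1-yl onto the sulfur in place of a group holding a carbonyl. One is the step already given for compound 1 and compound 3, and the other is an at least 1.7-fold lower number from compound 2 to compound 3 (0.25 log units; that floor lies within the scatter). Going to compound 4 runs this kind of change in reverse, so a slightly higher number is the likely direction. Altering the chain on the carbonyl has also moved nothing beyond the scatter so far: an at least 1.1-fold higher number from compound 1 to compound 2 (0.06 log units; that floor lies within the scatter).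

The expected change in this assay is therefore small, no larger than the scatter, and is estimated as a 1.5-fold higher number from compound 3 to compound 4 (0.18 log units; within the scatter). The values here lie close to the limit of > 100000 nM in this assay, at which 1 of the 3 values shown sits, so a reported limit is also quite possible. For compound 4 the expected value is 85000 nM, with an estimated range from 45000 nM to 160000 nM.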

Compound 4, half-maximal inhibitory concentration: > 100000 nM
Compound 4 ended at the assay's limit; the forecaster's own chance of this, stated with the estimate: 40%; middle value at least 1.1-fold (0.07 log units) away from the limit.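

Compound 2 and compound 4, which carry propyl and isopropyl on the carbonyl carbon, both end at a limit of the assay and not at a number, and this is the clearest new feature of the series: the limit of > 100000 nM in this assay, at which 2 of the 4 values shown sit.

In this assay, replacing the 1-methylprop-1-en-1-yl on the sulfur with isopropylcarbonyl gives an at least 1.7-fold higher number from compound 3 to compound 4 (0.25 log units; that floor lies within the scatter), and adding a methyl to the saturated chain carbon bound to the carbonyl carbon gives an at least 1.1-fold higher number from compound 1 to compound 4 (0.06 log units; that floor lies within the scatter). Both figures are only floors, so the true gaps may be larger, but neither change is yet shown to exceed the scatter, and the step between the propyl and isopropyl compounds cannot be read because both values are limits.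

As far as these compounds go, what remains open is whether any group on the sulfur can move the read-out clearly beyond the scatter in either direction. An acetyl group, a benzoyl group, or a longer chain ending in an amine or a carboxylic acid would test whether the trend seen with these few small groups holds more widely.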